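The source may hold more compounds than are shown below. What is called first, only, known or untested is meant among the compounds shown, and "the series" means these compounds.

Measured compounds:
- compound 1, `Cc1cc(C)c2cc(C#N)c(NCCNC(=O)c3ccncc3)nc2c1`: 7300 nM
- compound 2, `Cc1cc(C)c2cc(C#N)c(NCCNC(=O)c3ccccc3)nc2c1`: "not active" (no number reported)
- compound 3, `Cc1cc(C)c2cc(C#N)c(NCCNC(=O)c3cnccn3)nc2c1`: 6700 nM

In an in vitro assay on FRT cells with Cystic fibrosis transmembrane conductance regulator variant F508del (Homo sapiens) as the target, read by fluorescence, with a stated time of 24 h, at 37 degrees C, in the presence of a further agent that is not named here (a higher number here means that more compound is needed for the effect, a lower number that less compound is needed), compound 1 gives 7300 nM, the highest of the two numbers reported in this assay. Its nearest neighbour is compound 3, and the step of a 1.1-fold lower number from compound 1 to compound 3 (0.04 log units; within the scatter) lies within the scatter, so the two cannot be ordered. Among the measured compounds shown here, compound 2, which carries a phenyl group on the carbonyl carbon, gives "not active" (no number reported) in this assay; no step to it can be sized, and its result shows only that removing the ring nitrogen altogether leaves no measurable effect.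

Compound 4, `COc1ccc(C(=O)NCCNc2nc3cc(C)cc(C)c3cc2C#N)nc1`, is not yet measured. It differs from compound 1 in one place: 5-methoxypyridin-2-yl in place of pyridin-4-yl on a carbonyl carbon. For the measured compounds named here, the only measured step that bears on this change is the exchange of one nitrogen-containing six-membered aromatic ring for another, from compound 1 to compound 3, which stayed within the scatter. Going by the values given here, compound 4 keeps a ring nitrogen and adds a methoxy group, for which no measured step exists. The expected change is therefore a 1.2-fold lower number from compound 1 to compound 4 (0.09 log units; within the scatter), with no direction beyond the scatter. Compound 4 is estimated at 6000 nM, within 2500 nM to 15000 nM.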

Compound 4, half-maximal effective concentration: 2700 nM
Beside the measured number, compound 4's estimate is 2.2-fold (0.35 log units) above it; the range from low to high includes it.
By their numbers in this assay, from the lowest: compound 4; then compounds 3 and 1 (each within the scatter of the next).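

In this assay, the group on the carbonyl carbon now shifts the number beyond the scatter: 5-methoxypyridin-2-yl gives a 2.7-fold lower number from compound 1 to compound 4 (0.43 log units; beyond the scatter) and a 2.5-fold lower number from compound 3 to compound 4 (0.39 log units; beyond the scatter) as two modest steps. The exchange of pyridin-4-yl for pyrazin-2-yl had stayed within the scatter, so compound 4 shows that this position can respond to a change of ring and substituent together. Nothing given here accounts for the difference.

Compound 4 differs from compound 1 both in where the pyridine ring is attached and in carrying a methoxy group, and the compounds shown do not separate these two changes. On these data alone, how a plain pyridin-2-yl group, or a 5-ethoxypyridin-2-yl or 5-chloropyridin-2-yl group, would compare on the carbonyl carbon remains open.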